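A few compounds are considered here, and "the series" means these few. Any claim that something is new, unique, unknown or untested is made for them only; others in the source may bear on it.

Of the compounds shown here, two sharing one core have been measured in a functional assay on MKN-45 cells (Homo sapiens) for antiproliferative activity, read by MTT assay, with a stated time of 72 h, tested at 10 uM; on this read-out higher numbers stand for more inhibition at the one concentration tested (going by the name of the read-out) and lower numbers for less inhibition. Compound 1 `CCn1cc(-c2ccc(F)cc2)c(=O)c2c(Nc3ccc(Oc4ccnc(NC(=O)C5CC5)c4)c(F)c3)nccc21` carries an ethyl group on an aromatic nitrogen, and in this assay compound 1 gives 31.9%. Compound 2 `O=C(Nc1cc(Oc2ccc(Nc3nccc4[nH]cc(-c5ccc(F)cc5)c(=O)c34)cc2F)ccn1)C1CC1` has a hydrogen in that place; in this assay compound 2 gives 81.8%, the higher of the two numbers. Among the compounds with values here, the single step so far is a number 49.9 percentage points higher from compound 1 to compound 2 (beyond the scatter).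

Compound 3 `CC(C)(O)Cn1cc(-c2ccc(F)cc2)c(=O)c2c(Nc3ccc(Oc4ccnc(NC(=O)C5CC5)c4)c(F)c3)nccc21` is not yet measured. It differs from compound 2 in one place: 2-hydroxy-2-methylpropyl in place of hydrogen on an aromatic nitrogen. The measured step bears on this change in reverse, as a group on that same nitrogen was removed from compound 1 to compound 2 and gave a number 49.9 percentage points higher from compound 1 to compound 2 (beyond the scatter). Putting a group back on that nitrogen is therefore expected to lower the number, although the entering group is not ethyl, so the size is uncertain.

Compound 3 is estimated at 45%, with a range from 22% to 70%. This corresponds to an expected step of a number 36.8 percentage points lower from compound 2 to compound 3 (beyond the scatter).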

Compound 3, a percentage reported as inhibition, at one concentration (the size of the read-out at that concentration, not a potency): 44.3%
Compound 3: middle estimate off by 0.7 percentage points, on the high side; low and high end bracket the measured number.
By their numbers in this assay, from the lowest: compound 1; then compound 3; then compound 2.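

In this assay, a second, larger group on the aromatic nitrogen also lowers the number, with a number 37.5 percentage points lower from compound 2 to compound 3 (beyond the scatter), so the loss is not confined to ethyl. The entering group still matters: with 1-hydroxy-1-methylethyl in place of methyl on the saturated chain carbon bound to that nitrogen, there is a number 12.4 percentage points higher from compound 1 to compound 3 (beyond the scatter), which wins back only part of what substitution on this nitrogen costs. No measurement shown explains why these groups differ. The entering group adds both a hydroxyl and branching, so the compounds shown cannot say which of the two accounts for the gain over ethyl. Also open, on these data alone, is how a chain ending in an amine or a carboxylic acid would behave on this nitrogen, and whether any group there can match the unsubstituted compound 2.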